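This account rests on a few compounds, and the source may have more. Where it says the series, first, only, none or still open, it means among the compounds named here.

Measured compounds:
compound 1, `Cc1nn(C)c2c1C(c1ccccc1)=NCCN2`: 2.5 mg/kg
compound 2, `Cc1nn(C)c2c1C(c1cccc(Br)c1)=NCCN2`: 0.63 mg/kg
compound 3, `Cc1nn(C)c2c1C(c1cccc(N)c1)=NCCN2`: 2.5 mg/kg

The read-out throughout is a functional assay on the whole organism for positive allosteric modulation, with Rattus norvegicus as the target; on this read-out higher numbers stand for an effect only at larger amounts of compound and lower numbers for an effect already at smaller amounts. On these numbers compound 3 stands level with compound 1, the two together giving the highest values of the three, while compound 2 sits furthest away, with a 4.0-fold higher number from compound 2 to compound 3 (0.60 log units; beyond the scatter). The step from compound 1 to compound 3, no change at the digits printed from compound 1 to compound 3 (within the scatter), shows that placing an amino group on the aromatic carbon leaves the result unchanged, whereas the step of a 4.0-fold lower number from compound 1 to compound 2 (0.60 log units; beyond the scatter) shows that bromo at the same place improves it modestly.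

Compound 4, `Cc1nn(C)c2c1C(c1cccc(C#N)c1)=NCCN2`, differs from compound 3 as follows: cyano in place of amino on an aromatic carbon. Among the measured compounds shown here, no measured step involves a cyano group, so the expectation rests on the two substituent steps seen at this position: one neutral, one modestly favourable. Compound 4 is therefore estimated to lie between those outcomes, with an expected step of a 1.9-fold lower number from compound 3 to compound 4 (0.28 log units; within the scatter) in this assay. The value of compound 4 is estimated at 1.3 mg/kg, within a range from 0.4 mg/kg to 4 mg/kg.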

Compound 4, minimum effective dose: 1.25 mg/kg
Estimate against measurement, compound 4: 1.0-fold (0.02 log units) above, and the stated range covers the measured number.
By their numbers in this assay, from the lowest: compounds 2, 4, 1 and 3 (each within the scatter of the next, the first and the last beyond it).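

In this assay the cyano group cannot be told apart from amino (a 2.0-fold lower number from compound 3 to compound 4 (0.30 log units; within the scatter)) or from hydrogen (a 2.0-fold lower number from compound 1 to compound 4 (0.30 log units; within the scatter)). Among the compounds shown here, it also stays within the scatter of bromo (a 2.0-fold higher number from compound 2 to compound 4 (0.30 log units; within the scatter)), the one group that had separated from hydrogen and amino, so this position does not fall into two clear levels, and a group with 0 hydrogen-bond donors can replace amino without a change beyond the scatter. Nothing at hand gives a reason for any of these steps.

Still open, on these data alone, is whether groups such as chloro, methoxy or a carboxylic acid would fall nearer bromo or nearer hydrogen on this aromatic carbon. The compounds shown also leave open how any of these groups would behave elsewhere on the ring, since each one here sits meta to a large group.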